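The compounds below may be only part of what the source reports. "The series", "measured", "known", "first", "only" and "open" are said of these compounds alone.

Compound 1 `Cc1ncn2c(O)nncc12`: in a functional assay for inhibition, with Homo sapiens as the target (on this read-out lower numbers stand for stronger inhibition and higher numbers for weaker inhibition), compound 1 gives > 48000 nM, which is a limit of the assay rather than a number.
Compound 2 `CCCc1nc(C)c2c(C)nn(CC(=O)OCC)c(=O)n12`: compound 2 gives > 48000 nM, again only a limit.
Compound 3 `Oc1nncc2cncn12`: compound 3 gives > 48000 nM, again only a limit.

Compound 1 and compound 2 share no single counted difference; the difference between the two cores is not broken down here. From compound 1 to compound 3 the change is hydrogen in place of methyl on an aromatic carbon, and the step that the two limits leave unreadable from compound 1 to compound 3 cannot be read because both values are limits. The same kind of change, (hydrogen in place of methyl on an aromatic carbon), carries compound 2 to compound 4 `CCCc1nc(C)c2cnn(CC(=O)OCC)c(=O)n12`; here the place is a six-membered aromatic ring with 3 nitrogen rather than a five-membered ring with 2 nitrogen, and the surroundings described differ. All three measurements sit at the limit of > 48000 nM in this assay, at which 3 of the 3 values shown sit. Since compound 2 itself shows only a limit, the step from compound 2 to compound 4 is expected to be a step that the limit leaves unreadable from compound 2 to compound 4, essentially no change. Compound 4 is therefore estimated at 100000 nM, with a range from 30000 nM to 400000 nM, and most likely reported only as a limit.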

Compound 4, half-maximal inhibitory concentration: > 48000 nM
Compound 4 ended at the assay's limit (the forecaster's own chance of this, stated with the estimate: 85%); the middle value lies beyond the limit too.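

The step between compound 2 and compound 4 cannot be read, since both values are limits of the assay and not numbers: the limit of > 48000 nM in this assay, at which 4 of the 4 values shown sit.

The compounds shown leave open what hydrogen in place of methyl does to inhibition in this assay, and whether any of these cores gives a readable value.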